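Chain lengthening in the carbamate series: the next step

The source may report more compounds than this note shows. Statements on the series, on what has been measured and on what is new or still open speak of the compounds shown alone.

Measured so far in an assay on microsomes from intestine for inhibition of acyl-CoA:cholesterol acyltransferase (Oryctolagus cuniculus); a higher number here means a weaker inhibitor, a lower number a stronger inhibitor:
compound 1 `CCCCCCCCCCC(C)OC(=O)NC(=O)Oc1c(C(C)C)cccc1C(C)C` gives 49 nM
compound 2 `CCCCCCCCCCCCC(C)OC(=O)NC(=O)Oc1c(C(C)C)cccc1C(C)C` gives 17 nM

Compound 2 stands lowest of the two numbers; its nearest neighbour is compound 1, and the step of a 2.9-fold lower number from compound 1 to compound 2 (0.46 log units; beyond the scatter) lies beyond the scatter. Compound 3 `CCCCCCCCCCCCCCC(C)OC(=O)NC(=O)Oc1c(C(C)C)cccc1C(C)C` is not yet measured. It differs from compound 2 by ethyl in place of hydrogen on a saturated chain carbon, ten or more bonds along the chain from an oxygen next to a carbonyl group. Within the data shown here, the only step bearing on this change is the same kind of chain lengthening seen in a 2.9-fold lower number from compound 1 to compound 2 (0.46 log units; beyond the scatter), which was modest. A further step of similar kind is therefore expected in this assay, downward, though it may fall within the scatter. The estimate for compound 3 is 10 nM, range 4 nM to 30 nM, that is an expected step of a 1.7-fold lower number from compound 2 to compound 3 (0.23 log units; within the scatter).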

Compound 3, half-maximal inhibitory concentration: 58 nM
Compound 3: the middle estimate sits 5.8-fold (0.76 log units) below what was measured, and the stated range ends below it.
By their numbers in this assay, from the lowest: compound 2; then compounds 1 and 3 (each within the scatter of the next).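

The chain-lengthening change does not keep lowering the number in this assay: the same ethyl in place of hydrogen now reverses direction (a 3.4-fold higher number from compound 2 to compound 3 (0.53 log units; beyond the scatter)). Taken across the full span, butyl in place of hydrogen leaves the two ends of the set close together (a 1.2-fold higher number from compound 1 to compound 3 (0.07 log units; within the scatter)), so among these three compounds the lowest number lies at the middle chain, compound 2. No evidence on hand bears on this turn.

As far as these compounds go, whether a longer chain than that of compound 3 raises the number further stays open, as does the effect of an amine or a carboxylic acid in place of the chain.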